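A few compounds are considered here, and "the series" means these few. Any claim that something is new, unique, unknown or untested is made for them only; others in the source may bear on it.

Compound 1, `CCNCc1csc(-c2ccc(N3C[C@H](CNC(=O)c4ccc(Cl)s4)OC3=O)cc2)n1`: 890 nM
Compound 2, `O=C(NC[C@H]1CN(c2ccc(-c3nc(CN4CCCCC4)cs3)cc2)C(=O)O1)c1ccc(Cl)s1`: 3120 nM

In an assay on isolated protein (plasma) for inhibition of coagulation factor X (Oryctolagus cuniculus) (on this read-out higher numbers stand for weaker inhibition and lower numbers for stronger inhibition), compound 2 stands highest of the two measured numbers, separated from compound 1 by the step of a 3.5-fold higher number from compound 1 to compound 2 (0.54 log units; beyond the scatter). Compound 3, `CC1CCN(Cc2csc(-c3ccc(N4C[C@H](CNC(=O)c5ccc(Cl)s5)OC4=O)cc3)n2)CC1`, differs from compound 2 by methyl in place of hydrogen on a saturated ring carbon. Among the compounds with values here, the only measured step, a 3.5-fold higher number from compound 1 to compound 2 (0.54 log units; beyond the scatter), exchanges the whole amine rather than adding a methyl to the ring, so it bears on this change only loosely. For compound 3 a step of a 1.0-fold lower number from compound 2 to compound 3 (0.02 log units; within the scatter) is therefore expected in this assay, none beyond the scatter. Compound 3 is estimated at 3000 nM, with a range from 1200 nM to 8000 nM.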

Compound 3, half-maximal inhibitory concentration: 3780 nM
For compound 3 the middle estimate is 1.3-fold (0.10 log units) below the measured one, within the range that was stated.
By their numbers in this assay, from the lowest: compound 1; then compounds 2 and 3 (each within the scatter of the next).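

In this assay, a methyl on the saturated ring carbon three ring bonds from the ring nitrogen is tolerated: a 1.2-fold higher number from compound 2 to compound 3 (0.08 log units; within the scatter) is a step within the scatter. With 4-methylpiperidin-1-yl in place of ethylamino, the distance from the secondary amine persists, at a 4.2-fold higher number from compound 1 to compound 3 (0.63 log units; beyond the scatter). Nothing available explains either result. Still open, from the compounds shown here alone, is whether a hydroxyl or a larger group such as phenyl on that same ring carbon would be tolerated as well. Going by these compounds, whether a morpholin-4-yl ring would lie nearer to compound 1 also remains unknown.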